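This account rests on a few compounds, and the source may have more. Where it says the series, first, only, none or still open, it means among the compounds named here.

Measured compounds:
- compound 1 `C=CCn1c(=O)/c(=C\c2cccc(Cl)c2)[nH]c(=O)/c1=C\c1ccccc1OC`: 4900 nM
- compound 3 `C=CCn1c(=O)/c(=C\c2cccc(Cl)c2Cl)[nH]c(=O)/c1=C\c1ccccc1OC`: 1200 nM
- compound 2 `COc1ccccc1/C=c1/[nH]c(=O)/c(=C\c2ccccc2OC)n(C)c1=O`: "not determined" (no result reported)

Within the data shown here, in a functional assay on MOLT-4 cells (Homo sapiens) for cytotoxicity, read by CCK-8 assay, with a stated time of 72 h (a lower number here means a stronger inhibitor, a higher number a weaker inhibitor), compound 3 gives the lowest of the two numbers known; the nearest is compound 1, and the step of a 4.1-fold lower number from compound 1 to compound 3 (0.61 log units; beyond the scatter) separates them, the only single-point change measured so far. For compound 2 no result is reported in this assay, so its pair with compound 4 shows nothing.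

Compound 4 `C=CCn1c(=O)/c(=C\c2ccccc2OC)[nH]c(=O)/c1=C\c1ccccc1OC` differs from compound 3 by 2-methoxyphenyl in place of 2,3-dichlorophenyl on a double-bonded chain carbon bound to an aromatic carbon. Among the measured compounds shown here, no measured step swaps the dichlorophenyl for a methoxyphenyl at this place; the only bearing is indirect. The step of a 4.1-fold lower number from compound 1 to compound 3 (0.61 log units; beyond the scatter) shows that adding one chloro on that ring lowered the number beyond the scatter, so removing both chlorines and placing a methoxyphenyl there, which carries none, is expected to move the number up, likely by an amount of the same order as that step, possibly more since both chlorines go. Compound 4 is therefore expected to give a higher number than compound 3 in this assay, a step of a 4.2-fold higher number from compound 3 to compound 4 (0.62 log units; beyond the scatter). The estimate for compound 4 is 5000 nM, with a range of 1500 nM to 16000 nM.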

Compound 4, half-maximal inhibitory concentration: 13100 nM
Compound 4: the middle estimate sits 2.6-fold (0.42 log units) below what was measured; the range from low to high includes it.
By their numbers in this assay, from the lowest: compound 3; then compound 1; then compound 4.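

In this assay, the place on the double-bonded chain carbon bound to an aromatic carbon now tolerates more than chlorine variation alone shows: 2-methoxyphenyl in place of 2,3-dichlorophenyl gives an 11-fold higher number from compound 3 to compound 4 (1.04 log units; beyond the scatter), a wider step than a 4.1-fold lower number from compound 1 to compound 3 (0.61 log units; beyond the scatter) seen on adding one chloro. The comparison with the monochloro analogue gives a 2.7-fold higher number from compound 1 to compound 4 (0.43 log units; beyond the scatter), so 2-methoxyphenyl also falls behind 3-chlorophenyl, and the three groups at this place order as 2,3-dichlorophenyl, then 3-chlorophenyl, then 2-methoxyphenyl, with every step beyond the scatter. Nothing in hand gives a measured reason for this order, which stands here only as a description of the three compounds.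

The step to compound 4 removes chlorine and brings in methoxy in a single change, so the share of each remains unresolved, and an unsubstituted phenyl at this place would be needed to separate them. On these data alone, whether the trend extends beyond these three groups also remains open, for example to a phenyl carrying an amine or a carboxylic acid.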